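Morpholin-4-yl for Thiomorpholin-4-yl on Two Different Cores

A few compounds are considered here, and "the series" means these few. Any claim that something is new, unique, unknown or untested is made for them only; others in the source may bear on it.

The four compounds fall into two pairs built on two different cores. Compound 1 `Cc1cccc(/C(N)=N/NC(=S)N2CCSCC2)n1` and compound 2 `Cc1cccc(/C(N)=N/NC(=S)N2CCOCC2)n1` share one core, while compound 3 `N/C(=N\NC(=S)N1CCSCC1)c1ccc(F)cn1` and compound 4 `N/C(=N\NC(=S)N1CCOCC1)c1ccc(F)cn1` share another; how the two cores differ is not broken down here.

In a functional assay on HeLa cells (Homo sapiens) for cytotoxicity, read by MTT assay, with a stated time of 72 h, tested at 100 uM (a higher number here means more inhibition of growth at the concentration tested, a lower number less inhibition of growth), compound 1 gives 81.6%, and compound 2 gives 82.4%. The change between them is morpholin-4-yl in place of thiomorpholin-4-yl on a thiocarbonyl carbon, and it produced a number 0.8 percentage points higher from compound 1 to compound 2 (within the scatter), a step that lies within the usual scatter of such measurements. In this assay compound 3 gives 88.1%, and the gaps between this value and those of compound 1 and compound 2 are both within the scatter, so no order among the three can be claimed.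

Compound 4 has not yet been measured. It arises from compound 3 by morpholin-4-yl in place of thiomorpholin-4-yl on a thiocarbonyl carbon, the same change that turned compound 1 into compound 2, with the place around the thiocarbonyl carbon described in the same words for both pairs. The step from compound 3 to compound 4 in this assay is expected to be small, a number 0.1 percentage points lower from compound 3 to compound 4 (within the scatter), since the same change on the other core gave a number 0.8 percentage points higher from compound 1 to compound 2 (within the scatter). Compound 4 is therefore estimated at 88%, with a likely range from 80% to 94%.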

Compound 4, percent growth inhibition at one concentration: 81.2%
For compound 4 the middle estimate is 6.8 percentage points above the measured one; the range from low to high includes it.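

In this assay, morpholin-4-yl in place of thiomorpholin-4-yl on a thiocarbonyl carbon gave a number 6.9 percentage points lower from compound 3 to compound 4 (within the scatter), so on this core, as on the other, the change leaves a step that cannot be told apart from the usual variation between repeated measurements. Set beside each other, the steps on the two cores do not differ beyond what such measurements allow: the same change on two cores in this assay, a number 0.8 percentage points higher (within the scatter) from compound 1 to compound 2 and a number 6.9 percentage points lower (within the scatter) from compound 3 to compound 4, 7.7 percentage points apart, within the scatter of two such steps. For the compounds shown here, this shows that, within this pair of cores, the change was carried from one to the other without any step or any gap between steps rising beyond the scatter, but it does not show that the two steps are equal or that the change is without any effect, as each core offers only one pair, read at a single concentration.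

The compounds shown leave open how other groups on the thiocarbonyl carbon would read, such as piperidin-1-yl, a piperazine or an open-chain dimethylamino group. They also leave open whether the same change would give a similar step on a third core, or at concentrations lower than the one used in this assay.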